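Aryl ethynyl variation on the shared core: pyrimidin-2-yl

A few compounds are considered here, and "the series" means these few. Any claim that something is new, unique, unknown or untested is made for them only; others in the source may bear on it.

Three compounds sharing one core have been run in an assay on CHO cells for displacement of a labelled ligand from adenosine receptor A1 (Homo sapiens), read by scintillation counting, with a stated time of 60 min, tested at 10 uM; a lower number here means less inhibition, a higher number more inhibition at the concentration tested (going by the name of the read-out). Compound 1 `CNC(=O)[C@@]12C[C@@H]1[C@@H](n1cnc3c(NC)nc(C#Cc4cccc(F)c4)nc31)[C@H](O)[C@@H]2O` gives 14%. Compound 2 `CNC(=O)[C@@]12C[C@@H]1[C@@H](n1cnc3c(NC)nc(C#Cc4ccc(CO)cc4)nc31)[C@H](O)[C@@H]2O` gives 16% in this assay, and compound 3 `CNC(=O)[C@@]12C[C@@H]1[C@@H](n1cnc3c(NC)nc(C#Cc4cccnc4)nc31)[C@H](O)[C@@H]2O` gives 16%. Compound 1 thus stands with the other two rather than apart from them: the step of a number 2 percentage points higher from compound 1 to compound 2 (within the scatter) and the step of a number 2 percentage points higher from compound 1 to compound 3 (within the scatter) both lie inside the usual scatter, as does no change at the digits printed from compound 2 to compound 3 (within the scatter). Across the three the group on the triple-bonded carbon has been varied without any shift that can be read as real.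

The next compound, compound 4 `CNC(=O)[C@@]12C[C@@H]1[C@@H](n1cnc3c(NC)nc(C#Cc4ncccn4)nc31)[C@H](O)[C@@H]2O`, follows the same line. Its change from compound 1 is pyrimidin-2-yl in place of 3-fluorophenyl on a triple-bonded carbon. The two measured steps that bear on this, from compound 1 to compound 2 and from compound 1 to compound 3, each exchanged the same 3-fluorophenyl for another ring on the same triple-bonded carbon and produced no movement beyond the scatter. A ring with two heteroatoms in place of the carbocycle is a somewhat larger departure than either of those, but nothing in the data suggests that the direction would change.

Expected, therefore, for compound 4 in this assay: a step of a number 1 percentage points higher from compound 1 to compound 4 (within the scatter), that is, none beyond the scatter. The value for compound 4 is estimated at 15%, with a range from 4% to 28%.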

Compound 4, a percentage reported as inhibition, at one concentration (the size of the read-out at that concentration, not a potency): 25%
Estimate against measurement, compound 4: 10 percentage points below; low and high end bracket the measured number.
By their numbers in this assay, from the lowest: compounds 1, 2, 3 and 4 (each within the scatter of the next, the first and the last beyond it).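

In this assay, among these compounds, the group on the triple-bonded carbon is no longer without a readable effect: the series now holds a number 11 percentage points higher from compound 1 to compound 4 (beyond the scatter) for pyrimidin-2-yl in place of 3-fluorophenyl, the first step here to pass the scatter, though only a modest one. That step does not set pyrimidin-2-yl apart from every other ring, as the series also shows a number 9 percentage points higher from compound 3 to compound 4 (within the scatter) and a number 9 percentage points higher from compound 2 to compound 4 (within the scatter) with both lying inside the scatter, so compound 4 separates from compound 1 alone and cannot be told from compound 2 or compound 3. No measurement at hand accounts for the step, and the shift from no hydrogen-bond acceptors in 3-fluorophenyl to two in pyrimidin-2-yl remains a count rather than an explanation.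

Still open, from the compounds shown here alone, is whether pyridin-2-yl on the same triple-bonded carbon would read with compound 4 or with compound 3, and how an amine, a carboxylic acid or a longer chain on the ring would read in this assay at the tested concentration. Open too, going by these compounds, is whether a step of this size at one concentration would hold up as a difference in potency, which a full concentration series could settle.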